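Adding a Propyl Group to the One Measured Compound

The source may report more compounds than this note shows. Statements on the series, on what has been measured and on what is new or still open speak of the compounds shown alone.

Compound 1 `COCOc1cc(O)ccc1/C=C/C(=O)c1ccc(O)cc1O` gives "not determined" (no result reported)
Compound 2 `COc1cc(OC)c(OC)cc1/C=C/C(=O)c1ccc(O)cc1O` gives 31800 nM
Compound 3 `O=C(/C=C/c1ccc(Cl)cc1Cl)c1ccc(O)cc1O` gives "not determined" (no result reported)

These three results come from a functional assay on MCF7 cells (Homo sapiens) for inhibition, read by sulforhodamine B assay, with a stated time of 48 h (on this read-out lower numbers stand for stronger inhibition of growth and higher numbers for weaker inhibition of growth), and only compound 2 has a number. With no result reported for compound 1 or compound 3, compound 2 cannot be ranked against either of them, and its value cannot be called high or low within this small set.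

The next compound to be tested is compound 4 `CCCc1c(O)ccc(C(=O)/C=C/c2cc(OC)c(OC)cc2OC)c1O` which keeps the core of compound 2 and changes it in one place (propyl in place of hydrogen on an aromatic carbon). The new propyl group sits ortho to two hydroxy groups.

For the measured compounds named here, no two measured compounds differ by a single change, so the data offer no direct guide to the effect of this one. A modest move toward stronger inhibition of growth in this assay is expected, though a result within the usual scatter would be no surprise. Going by the values given here, the only anchor is compound 2 at 31800 nM and the range must therefore stay wide. The expected change is a 2.0-fold lower number from compound 2 to compound 4 (0.30 log units; within the scatter) and it is only an estimate. For compound 4 the estimated value is 16000 nM (expected range 5000 nM to 45000 nM).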

Compound 4, concentration for 50% growth inhibition: 9100 nM
Compound 4: the middle estimate sits 1.8-fold (0.25 log units) above what was measured; low and high end bracket the measured number.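

In this assay, putting propyl in place of hydrogen on the aromatic carbon ortho to two hydroxy groups gives a 3.5-fold lower number from compound 2 to compound 4 (0.54 log units; beyond the scatter). For the compounds shown here, this is the first direct comparison in the set: the earlier compounds offered only one number and no pair differing in one place, so nothing could be said about this position until now. It shows that this position can carry a propyl group with growth inhibition kept and modestly strengthened, although no measured evidence here says why the number falls.

A single step cannot show whether the trend depends on chain length, so a shorter methyl or a longer butyl chain at the same carbon could go either way, and an amine or a carboxylic acid there could behave quite differently from propyl. It also leaves open whether the same propyl group would produce a similar step if the groups elsewhere in the molecule were different, since this change is seen on the core of compound 2 alone.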